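Cytotoxicity notes on a piperazinyl aryl ketone series

The source may hold more compounds than are shown below. What is called first, only, known or untested is meant among the compounds shown, and "the series" means these compounds.

Measured compounds:
compound 1 `O=C(CCN1CCN(c2ccc(C(F)(F)F)cc2)CC1)c1ccc(F)c(F)c1`: 14000 nM
compound 2 `O=C(CCN1CCN(c2ccc(Cl)cc2)CC1)c1ccc(F)c(F)c1`: 86200 nM
compound 3 `O=C(CCN1CCN(c2ccc(C(F)(F)F)cc2)CC1)c1ccc(OC(F)(F)F)cc1`: 64900 nM

The read-out throughout is an ADME assay on Vero cells (Chlorocebus sabaeus) for cytotoxicity, read by resazurin assay, with a stated time of 72 h; a higher number here means a weaker inhibitor, a lower number a stronger inhibitor. Within this set of three, compound 1 gives 14000 nM, the lowest number of the three. Compound 2 shares its core with compound 1 and differs from it by chloro in place of trifluoromethyl on an aromatic carbon; compound 2 gives 86200 nM, and the step is a 6.2-fold higher number from compound 1 to compound 2 (0.79 log units; beyond the scatter). Compound 3 gives 64900 nM. How the core of compound 3 differs from the core of compound 1 is not broken down here. Compound 3 stands second highest of the three; its value and that of compound 2 lie within the scatter of each other, so no order between them is drawn, while the gap to compound 1 lies beyond the scatter.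

Compound 4 `O=C(CCN1CCN(c2ccc(Cl)cc2)CC1)c1ccc(OC(F)(F)F)cc1` is not yet measured. It differs from compound 3 by chloro in place of trifluoromethyl on an aromatic carbon, the same change that takes compound 1 to compound 2, made here on the core of compound 3. Going by the values given here, the single measured instance of that change is the step of a 6.2-fold higher number from compound 1 to compound 2 (0.79 log units; beyond the scatter), so compound 4 is expected to show a step in the same direction and of comparable size, estimated as a 2.5-fold higher number from compound 3 to compound 4 (0.39 log units; beyond the scatter). Among the compounds with values here, only one example of the change exists, so this expectation is held with some caution. Compound 4 is thus expected to give about 160000 nM, with a plausible range from 60000 nM to 400000 nM; a value this high may be reported only as a limit of this assay.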

Compound 4, half-maximal inhibitory concentration: 95600 nM
For compound 4 the middle estimate is 1.7-fold (0.22 log units) above the measured one; the measured number falls inside the stated range.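

In this assay, chloro in place of trifluoromethyl on the core of compound 3 gives a 1.5-fold higher number from compound 3 to compound 4 (0.17 log units; within the scatter), a step that cannot be told apart from the scatter of repeated measurements on this core. The same change therefore does not carry over at a fixed size between the two cores in this series, and the gap between its two steps is itself larger than scatter alone would account for: the same change on two cores in this assay, a 6.2-fold higher number (0.79 log units; beyond the scatter) from compound 1 to compound 2 and a 1.5-fold higher number (0.17 log units; within the scatter) from compound 3 to compound 4, 4.2-fold (0.62 log units) apart, beyond the scatter of two such steps. Going by these compounds alone, what this does not show is why the size depends on the core or how the change would behave on a third core, since only one step beyond the scatter and one within it are available, and a single pair of cores cannot separate a general trend from a feature of these particular compounds.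

Still open, as far as these compounds go, is whether the step on the core of compound 1 or the one on the core of compound 3 is the more usual, which would take further cores carrying the same pair of groups to settle. Also open, from the compounds shown here alone, is how other groups in the place of trifluoromethyl, such as a nitrile, a methoxy group or a carboxylic acid, or a longer chain leading to the carbonyl, would read in this assay.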